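Alpha-methyl on the chain: compound 1 to compound 3

This account rests on a few compounds, and the source may have more. Where it says the series, first, only, none or still open, it means among the compounds named here.

Measured compounds in a functional assay with platelet-activating factor receptor (Cavia porcellus) as the target; a higher number here means that more compound is needed for the effect, a lower number that less compound is needed:
Compound 1, `O=C(/C=C/C=C(c1cccc(F)c1)c1cccc(F)c1)NCCCCc1cccnc1`, gives 0.34 mg/kg.
Compound 2, `COc1ccc(C(=C/C=C/C(=O)Nc2ccc(-c3cccnc3)cc2)c2ccc(OC)cc2)cc1`, gives 0.15 mg/kg.

Of the two numbers shown, compound 1 carries the higher one, so more of it is needed for the effect. The nearest comparison is compound 2, which gives a lower number, and the gap between the two lies beyond the usual scatter; since the two structures differ in several places at once, no single change can be tied to that gap.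

Compound 3, `C[C@H](CCCc1cccnc1)NC(=O)/C=C/C=C(c1cccc(F)c1)c1cccc(F)c1`, is not yet measured. Relative to compound 1 it has methyl in place of hydrogen on a saturated chain carbon bound to an amide-type nitrogen and a saturated chain carbon. Among the measured compounds shown here, no measured pair in this set shows what such a change does, so there is no step to lean on. With nothing in the data pointing in either direction, the expectation for compound 3 is a number close to that of compound 1, and the step of a 1.1-fold lower number from compound 1 to compound 3 (0.03 log units; within the scatter) is expected to stay within the scatter. For compound 3 the estimated result in this assay is 0.32 mg/kg, with a likely range from 0.11 mg/kg to 0.95 mg/kg.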

Compound 3, dose for 50% inhibition: 0.22 mg/kg
Estimate against measurement, compound 3: 1.5-fold (0.16 log units) above; measured number inside the range.
By their numbers in this assay, from the lowest: compounds 2, 3 and 1 (each within the scatter of the next, the first and the last beyond it).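

In this assay, putting a methyl in place of hydrogen on a saturated chain carbon bound to an amide-type nitrogen and a saturated chain carbon gives a 1.5-fold lower number from compound 1 to compound 3 (0.19 log units; within the scatter). Among the compounds shown here, this is the first direct reading of any single change in this set, since compound 1 and compound 2 differ in several places at once, and it shows that this chain carbon can carry a methyl, in the one spatial arrangement present in compound 3, without the number moving beyond the scatter. Nothing measured here explains the result or shows what the methyl does to the compound, so it stands only as an observation about the dose needed.

The compounds shown leave open whether the mirror-image arrangement at this carbon would give a similar number, and whether a larger group, such as an ethyl or a phenyl, or a group of a different kind, such as a hydroxyl or an amine, would also leave the number within the scatter. They also leave open whether the same methyl would behave alike on the core of compound 2.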